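The source may hold more compounds than are shown below. What is called first, only, known or untested is meant among the compounds shown, and "the series" means these compounds.

Working notes on the sorbamide series.

Compound 1 `C/C=C/C=C/C(=O)Nc1ccc(OC)cc1` gives 2.28 in a physicochemical assay for lipophilicity; on this read-out higher numbers stand for higher lipophilicity and lower numbers for lower lipophilicity. Compound 2 `C/C=C/C=C/C(=O)Nc1ccc(Cl)cc1` gives 3.05 in this assay. Compound 3 `C/C=C/C=C/C(=O)Nc1ccccc1OC` gives 2.28 in this assay, level with compound 1, and the two together stand lowest of the three values. Compound 4 `C/C=C/C=C/C(=O)Nc1ccccc1Cl` is not yet measured.

The change from compound 1 to compound 2 is chloro in place of methoxy on an aromatic carbon, and it gives a number 0.77 log units higher from compound 1 to compound 2 (beyond the scatter). The change from compound 3 to compound 4 is chloro in place of methoxy on an aromatic carbon. Both changes are chloro in place of methoxy on an aromatic carbon, but the place differs: in the first it is para to a group of 8 heavy atoms, in the second ortho to a group of 8 heavy atoms, so it is the same kind of change rather than the same change. The difference between the core of compound 1 and the core of compound 3 is not broken down here; their values in this assay are within the scatter of each other.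

Because the earlier step gave a number 0.77 log units higher from compound 1 to compound 2 (beyond the scatter), a step of about a number 0.72 log units higher from compound 3 to compound 4 (beyond the scatter) is expected from compound 3 to compound 4 in this assay. Compound 4 is therefore estimated at 3, within 2.6 to 3.4.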

Compound 4, partition coefficient: 3.05
Estimate against measurement, compound 4: 0.05 log units below, within the range that was stated.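

In this assay, chloro in place of methoxy gives a number 0.77 log units higher from compound 3 to compound 4 (beyond the scatter), and the same kind of change on the core of compound 1 gives a number 0.77 log units higher from compound 1 to compound 2 (beyond the scatter), so across these two cores the change carries over with no difference at the digits printed. This is one repeat of one replacement on two closely related cores, with the change ortho to a group of 8 heavy atoms in the second case, and it does not show that the step would hold on any further core or for any other replacement. Nothing measured here bears on why the step has this size.

The compounds shown leave open whether a group other than methoxy and chloro, such as an amine or a carboxylic acid, would behave the same way on both cores. They also leave open whether the step would survive a longer chain in place of the sorbamide chain.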